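The compounds below may be only part of what the source reports. "The series", "measured", "known", "first", "only" and "open" are said of these compounds alone.

Of the compounds shown here, three that share one core have been tested in a functional assay on M21 cells (Homo sapiens) for antiproliferative activity, read by sulforhodamine B assay, with a stated time of 48 h; a lower number here means a stronger inhibitor, a higher number a weaker inhibitor. Compound 1 `CC(C)c1ccccc1OS(=O)(=O)c1ccc(NC(=O)CCl)cc1` gives 3900 nM. Compound 2 `CC(C)c1ccccc1OS(=O)(=O)c1ccc(NC(=O)CCCl)cc1` gives 14000 nM, and compound 3 `CC(C)c1ccccc1OS(=O)(=O)c1ccc(NC(=O)CCCCl)cc1` gives 5100 nM. On these numbers compound 3 stands second highest of the three: its nearest neighbour is compound 1, and that gap, a 1.3-fold higher number from compound 1 to compound 3 (0.12 log units; within the scatter), lies within the scatter, while the gap to compound 2, a 2.7-fold lower number from compound 2 to compound 3 (0.44 log units; beyond the scatter), lies beyond it. The remaining step, a 3.6-fold higher number from compound 1 to compound 2 (0.56 log units; beyond the scatter), shows the other side of the same chain lengthening.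

Compound 4 `CCCCCNC(=O)Nc1ccc(S(=O)(=O)Oc2ccccc2C(C)C)cc1` differs from compound 3 in one place: pentylamino in place of 3-chloropropyl on a carbonyl carbon. The measured steps all concern making a chlorine-bearing chain on this carbonyl carbon longer or shorter; none swaps that chain for a nitrogen-bearing one. For the measured compounds named here, they bear on the new step only by showing how far changes at this position have moved this assay so far, which is modestly, and in both directions. A step of similar modest size is therefore expected for compound 4, with the direction uncertain and a higher number judged somewhat more likely. Compound 4 is expected to give 12000 nM, between 3500 nM and 40000 nM. The expected step is a 2.4-fold higher number from compound 3 to compound 4 (0.37 log units; beyond the scatter).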

Compound 4, half-maximal inhibitory concentration: 4600 nM
Beside the measured number, compound 4's estimate is 2.6-fold (0.42 log units) above it, within the range that was stated.
By their numbers in this assay, from the lowest: compounds 1, 4 and 3 (each within the scatter of the next); then compound 2.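

In this assay, for the compounds shown here, the earlier compounds only varied the length of a chlorine-bearing chain on this carbonyl carbon, whereas compound 4 carries no chlorine and has a nitrogen with its hydrogen attached there instead. Even so, the swap gives a 1.1-fold lower number from compound 3 to compound 4 (0.04 log units; within the scatter) and, against the shortest chain, a 1.2-fold higher number from compound 1 to compound 4 (0.07 log units; within the scatter), so in this assay a chlorine on the chain is not required to reach the level of compound 1 and compound 3. Only the comparison with the 2-chloroethyl compound shows a real difference, a 3.0-fold lower number from compound 2 to compound 4 (0.48 log units; beyond the scatter), which leaves compound 2 as the weakest of the four, and nothing measured here explains this pattern.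

Because pentylamino differs from 3-chloropropyl in its nitrogen, its chain length and its lack of chlorine all at once, these compounds cannot show which of those features matters, although a plain pentyl group on the carbonyl carbon would help separate them, and a 2-chloroethylamino group would show whether chlorine changes the result once the nitrogen is present. On these data alone, it also remains open how much change this site accepts beyond simple chains, for example a chain ending in a carboxylic acid or an amine, or a much longer chain.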